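Trading an aryl amide for an ester-bearing amide

The compounds below may be only part of what the source reports. "The series", "measured", "known", "first", "only" and "open" are said of these compounds alone.

Of the compounds shown here, three sharing one core have been tested in an assay on cells for agonist activity at vitamin D3 receptor (Homo sapiens), with a stated time of 96 h; a lower number here means that less compound is needed, a higher number that more compound is needed for the effect. Compound 1 `CCn1c(C(=O)NCCCN(C)C)ccc1C(CC)(CC)c1ccc(OCCC(O)(CC)CC)c(C)c1` gives 5 nM and compound 2 `C#CC(C)OC(=O)c1ccc(C(CC)(CC)c2ccc(OCCC(O)(CC)CC)c(C)c2)n1CC` gives 2650 nM. Compound 3 `CCn1c(C(=O)Nc2ccc(OC(F)(F)F)cc2)ccc1C(CC)(CC)c1ccc(OCCC(O)(CC)CC)c(C)c1` reaches only the limit of > 10000 nM, so its exact potency is not known. The steps of an at least 2000-fold higher number from compound 1 to compound 3 (3.30 log units; beyond the scatter) and an at least 3.7-fold higher number from compound 2 to compound 3 (0.57 log units; beyond the scatter) place compound 3 at the weak end of what has been measured. Compound 4 `CCC(C)C(NC(=O)c1ccc(C(CC)(CC)c2ccc(OCCC(O)(CC)CC)c(C)c2)n1CC)C(=O)OC` differs from it by a group of 9 heavy atoms (7 carbon, 2 oxygen; no ring) in place of a group of 11 heavy atoms (7 carbon, 1 oxygen, 3 fluorine; one six-membered aromatic ring of carbon only), on an amide-type nitrogen. The step of an at least 2000-fold higher number from compound 1 to compound 3 (3.30 log units; beyond the scatter) bears most closely: compound 1 also carries a group without a ring on that nitrogen, although the group entering in compound 4 has no amine. Compound 4 is therefore expected to give 500 nM, between 50 nM and 8000 nM. This estimate means the step of an at least 20-fold lower number from compound 3 to compound 4 (1.30 log units; beyond the scatter).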

Compound 4, half-maximal effective concentration: > 10000 nM
Compound 4: no number, only a limit; the forecaster's own chance of this, stated with the estimate: 25%; middle value at least 20-fold (1.30 log units) from the limit.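

In this assay compound 4 gives > 10000 nM, which is a limit and not a number. Removing the ring from the group on the amide-type nitrogen is therefore not enough to restore potency: the change shows an at least 2000-fold higher number from compound 1 to compound 4 (3.30 log units; beyond the scatter), and the comparison with the ester shows an at least 3.7-fold higher number from compound 2 to compound 4 (0.57 log units; beyond the scatter). Compound 3 and compound 4 cannot be put in order, and the step between them cannot be read: the limit of > 10000 nM in this assay, at which 2 of the 4 values shown sit.

Still open, going by these compounds, is whether the amine of compound 1 is what matters on this nitrogen. A shorter chain ending in dimethylamino, or a carboxylic acid in place of the methyl ester of compound 4, would speak to this.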